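Notes on a pyrazoline series: fluoro to trifluoromethyl step

This account rests on a few compounds, and the source may have more. Where it says the series, first, only, none or still open, it means among the compounds named here.

Measured compounds:
compound 1, `COc1ccc(C2=NN(c3ccc(-c4ccccc4)nn3)C(c3ccccc3)C2)cc1`: > 100000 nM in a functional assay on Caco-2 cells (Homo sapiens) for antiproliferative activity, read by MTT assay, with a stated time of 24 h; on this read-out lower numbers stand for stronger inhibition and higher numbers for weaker inhibition
compound 2, `COc1ccc(C2=NN(c3ccc(-c4ccccc4)nn3)C(c3ccc(F)cc3)C2)cc1`: 18100 nM in this assay

Compound 1 returns only the upper limit of this assay and not a number (the limit of > 100000 nM in this assay, at which 1 of the 2 values shown sits). For the measured compounds named here, compound 2 is the only compound of the pair with a numerical value, so it cannot be ranked against anything measured. Going by the values given here, the one measured step, an at least 5.5-fold lower number from compound 1 to compound 2 (0.74 log units; beyond the scatter), is a fluoro in place of hydrogen on an aromatic carbon.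

Compound 3, `COc1ccc(C2=NN(c3ccc(-c4ccccc4)nn3)C(c3ccc(C(F)(F)F)cc3)C2)cc1`, is not yet measured. Its change from compound 2 is trifluoromethyl in place of fluoro on an aromatic carbon; cut one bond further out, it reads 4-fluorophenyl to 4-(trifluoromethyl)phenyl. Among the compounds with values here, no measured step covers this exchange. The step from compound 1 to compound 2 touches the same aromatic carbon, but it swaps hydrogen for fluoro, not fluoro for trifluoromethyl, so it carries only weak weight here. A step within the scatter in this assay, in either direction, is expected; the estimate for compound 3 is 14000 nM, between 3500 nM and 56000 nM, which as a step means a 1.3-fold lower number from compound 2 to compound 3 (0.11 log units; within the scatter).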

Compound 3, half-maximal inhibitory concentration: 65000 nM
Beside the measured number, compound 3's estimate is 4.6-fold (0.67 log units) below it; measured number outside the range, above it.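

At this aromatic carbon, the exchange of fluoro for trifluoromethyl is not neutral in this assay: there is a 3.6-fold higher number from compound 2 to compound 3 (0.56 log units; beyond the scatter), so the read-out depends on which group replaces hydrogen and not only on whether hydrogen is replaced. With steps beyond the scatter to both compound 1 and compound 3, compound 2 is the strongest of the three, while trifluoromethyl in place of hydrogen gives only an at least 1.5-fold lower number from compound 1 to compound 3 (0.18 log units; that floor lies within the scatter), so compound 3 cannot be firmly separated from compound 1. That last comparison gives a floor and not a size, and the step rests on a limit of the assay: the limit of > 100000 nM in this assay, at which 1 of the 3 values shown sits.

From the compounds shown here alone, it remains open whether a chloro group, a nitrile, an amine or a carboxylic acid on this same aromatic carbon would fall nearer compound 2 or nearer compound 3. Also open, going by these compounds, is whether the order of fluoro and trifluoromethyl holds once the methoxy group of the shared core is exchanged, or in any read-out other than this assay.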